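The source may hold more compounds than are shown below. What is called first, only, known or untested is meant among the compounds shown, and "the series" means these compounds.

Compound 1 `CCCc1ccc(/C=C/C(=O)Nc2ccc3nc(CCC)cc(N)c3c2)cc1` and compound 2 `CCCc1cc(N)c2cc(NC(=O)/C=C/c3cccc(Cl)c3)ccc2n1` share the same core and differ only on the aromatic ring at the end of the double-bonded chain. In an assay on isolated protein for displacement of a labelled ligand from melanin-concentrating hormone receptor 1 (Homo sapiens) (a higher number here means a weaker inhibitor, a lower number a stronger inhibitor), compound 1 gives 4 nM, while compound 2 gives 1100 nM, the higher of the two numbers; the step of a 280-fold higher number from compound 1 to compound 2 (2.44 log units; beyond the scatter) shows how strongly that ring's substituent matters. Compound 3 `CCCc1cc(N)c2cc(NC(=O)/C=C/c3ccc(Cl)c(Cl)c3)ccc2n1` carries chloro in place of hydrogen on an aromatic carbon, para to a large group. Among the compounds with values here, no measured step shares this change, so its direction is uncertain; a moderate shift is expected, a 2.8-fold lower number from compound 2 to compound 3 (0.44 log units; beyond the scatter). Compound 3 is therefore estimated at 400 nM, within 80 nM to 2000 nM.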

Compound 3, half-maximal inhibitory concentration: 60 nM
Beside the measured number, compound 3's estimate is 6.7-fold (0.82 log units) above it; measured number outside the range, below it.
By their numbers in this assay, from the lowest: compound 1; then compound 3; then compound 2.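

Adding one chloro on the aromatic carbon ortho to the existing chloro group gives an 18-fold lower number from compound 2 to compound 3 (1.26 log units; beyond the scatter) from a single heavy atom, so this position on the end ring strongly affects the result. The change to 3,4-dichlorophenyl still falls short of 4-propylphenyl, as a 15-fold higher number from compound 1 to compound 3 (1.18 log units; beyond the scatter) shows. Nothing measured here explains the effect of the added chloro.

Going by these compounds, whether a methyl group, a methoxy group or an amine at this same position would match or outdo chloro remains open. So does the effect of a chloro here without the first chloro.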